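Series notes: trimming one methoxy on the pyrazole-linked ring

A few compounds are considered here, and "the series" means these few. Any claim that something is new, unique, unknown or untested is made for them only; others in the source may bear on it.

Compound 2 `COc1cc(-c2cc(/C=C/C(=O)c3ccc(N)cc3)[nH]n2)cc(OC)c1OC` gives 108% in a functional assay on HCC 2998 cells (Homo sapiens) for cytotoxicity, read by sulforhodamine B assay, with a stated time of 48 h, tested at 0.01 uM (on this read-out lower numbers stand for a stronger effect and higher numbers for a weaker effect at the one concentration tested), and stands highest of the three numbers recorded. Among the measured compounds shown here, compound 1 `COc1ccc(-c2cc(/C=C/C(=O)c3ccc(N)cc3)[nH]n2)cc1` gives 96% in the same assay, and compound 3 `COc1ccc(C(=O)/C=C/c2cc(-c3cc(OC)c(OC)c(OC)c3)n[nH]2)cc1OC` gives 93%; the only step recorded within a single change, a number 15 percentage points lower from compound 2 to compound 3 (beyond the scatter), concerns the aryl group on the carbonyl carbon and not the ring carrying the methoxy groups.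

Compound 4 `COc1ccc(-c2cc(/C=C/C(=O)c3ccc(N)cc3)[nH]n2)cc1OC` differs from compound 2 by hydrogen in place of methoxy on an aromatic carbon. For the measured compounds named here, no recorded step tracks this particular change: the step from compound 2 to compound 3 alters a different part of the molecule, and compound 1 differs from compound 4 as well in the number of methoxy groups, so its value serves only as a loose anchor. Compound 1 and compound 2 lie beyond the scatter of each other, which suggests the methoxy count on this ring can move the read-out by a modest amount, but the direction for a single removal is not fixed by any shown step.

The expectation is therefore a step of a number 8 percentage points lower from compound 2 to compound 4 (within the scatter), sitting between what compound 1 and compound 2 show. Compound 4 is estimated at 100%, with a range of 88% to 113%.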

Compound 4, a percentage reported as activity, at one concentration (the size of the read-out at that concentration, not a potency): 102%
Compound 4: the middle estimate sits 2 percentage points below what was measured, within the range that was stated.
By their numbers in this assay, from the lowest: compounds 3, 1, 4 and 2 (each within the scatter of the next, the first and the last beyond it).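

In this assay the methoxy ortho to a methoxy group and meta to a large group can now be read as a single change: hydrogen in its place gives a number 6 percentage points lower from compound 2 to compound 4 (within the scatter) on the ring carrying the methoxy groups. The neighbouring single change, methoxy in place of hydrogen on an aromatic carbon, gives a number 6 percentage points higher from compound 1 to compound 4 (within the scatter) and so also stays inside the usual spread, which means that neither change separates compound 4 from the compound it is paired with at the one concentration tested. No independent measurement is at hand to account for these two steps.

Still open, going by these compounds, is whether a different group on this aromatic carbon, such as an amine, a hydroxyl or a longer alkoxy chain, would give a step beyond the scatter in this assay where hydrogen and methoxy do not. Also open is whether the same exchange of methoxy for hydrogen would read alike with 3,4-dimethoxyphenyl on the carbonyl carbon in place of 4-aminophenyl, and a single concentration says nothing about potency for any of these compounds.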